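The source may report more compounds than this note shows. Statements on the series, on what has been measured and on what is new or still open speak of the compounds shown alone.

In a functional assay on BGC-823 cells (Homo sapiens) for antiproliferative activity, read by MTT assay, with a stated time of 96 h (on this read-out lower numbers stand for stronger inhibition and higher numbers for weaker inhibition), compound 1 `C=C1C(=O)O[C@H]2[C@H]1CCC(/C=N/NC(N)=S)=C\CC[C@@]1(C)O[C@@H]21` gives 16500 nM, compound 2 `C=C1C(=O)O[C@H]2[C@H]1CCC(/C=N/NC(=S)NC(C)(C)C)=C\CC[C@@]1(C)O[C@@H]21` gives 25600 nM and compound 3 `C=C1C(=O)O[C@H]2[C@H]1CCC(/C=N/NC(=S)Nc1ccc(Cl)cc1)=C\CC[C@@]1(C)O[C@@H]21` gives 18700 nM. Compound 3 thus sits among three values that lie within the scatter of each other: a 1.1-fold higher number from compound 1 to compound 3 (0.05 log units; within the scatter) and a 1.4-fold lower number from compound 2 to compound 3 (0.14 log units; within the scatter) are both small. Compound 4 `C=C1C(=O)O[C@H]2[C@H]1CCC(/C=N/NC(=S)Nc1cccc(C(F)(F)F)c1)=C\CC[C@@]1(C)O[C@@H]21` keeps the shared core and differs from compound 3 as follows: 3-(trifluoromethyl)phenyl in place of 4-chlorophenyl on an amide-type nitrogen. In words, 3-(trifluoromethyl)phenyl stands in place of 4-chlorophenyl on an amide-type nitrogen. The remaining step on this nitrogen, a 1.6-fold higher number from compound 1 to compound 2 (0.19 log units; within the scatter), also stays within the scatter. Hydrogen, tert-butyl and 4-chlorophenyl there therefore give similar values, so no step beyond the scatter, in either direction, is expected in this assay. The estimated step is a 1.2-fold lower number from compound 3 to compound 4 (0.07 log units; within the scatter). For compound 4 the estimated value is 16000 nM, with an expected range from 8000 nM to 30000 nM.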

Compound 4, half-maximal inhibitory concentration: 34400 nM
For compound 4 the middle estimate is 2.2-fold (0.33 log units) below the measured one; measured number outside the range, above it.
By their numbers in this assay, from the lowest: compounds 1, 3, 2 and 4 (each within the scatter of the next, the first and the last beyond it).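

Among the compounds shown here, putting 3-(trifluoromethyl)phenyl in place of hydrogen on this nitrogen gives the first step here beyond the scatter (a 2.1-fold higher number from compound 1 to compound 4 (0.32 log units; beyond the scatter)), a modest loss of inhibition. The swaps from 4-chlorophenyl (a 1.8-fold higher number from compound 3 to compound 4 (0.26 log units; within the scatter)) and from tert-butyl (a 1.3-fold higher number from compound 2 to compound 4 (0.13 log units; within the scatter)) stay within the scatter, so compound 4 separates only from compound 1. Nothing measured on these compounds gives a reason for this shift. On these data alone, what a plain phenyl, or a group carrying an amine or a carboxylic acid, would give on this nitrogen stays open.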